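The source may hold more compounds than are shown below. What is called first, only, known or untested is meant among the compounds shown, and "the series" means these compounds.

Measured in a functional assay on LOX IMVI cells (Homo sapiens) for inhibition, read by sulforhodamine B assay, with a stated time of 48 h; a higher number here means a weaker inhibitor of growth, a lower number a stronger inhibitor of growth:
Compound 1 `O=C(Nc1cccc(-n2cc(-c3ccncc3)c(-c3ccc(Cl)c(O)c3)n2)c1)Nc1cccc(C(F)(F)F)c1`: 2530 nM
Compound 2 `COc1cc(-c2nn(-c3cccc(NC(=O)c4cccc(C(F)(F)F)c4)c3)cc2-c2ccncc2)ccc1Cl`: 1390 nM

In this assay, compound 2 gives 1390 nM and compound 1 gives 2530 nM. These two values lie within the usual scatter of each other, so the pair cannot be ranked. Compound 3 `COc1cc(-c2nn(-c3cccc(NC(=O)c4ccccc4)c3)cc2-c2ccncc2)ccc1Cl` keeps the core of compound 2 and carries hydrogen in place of trifluoromethyl on an aromatic carbon, so that 3-(trifluoromethyl)phenyl becomes phenyl (hydrogen in place of trifluoromethyl on an aromatic carbon). No comparison among the measured compounds isolates this change, which leaves the expectation loose. A somewhat weaker inhibitor of growth seems likelier than a stronger one, though a result within the scatter would be no surprise. The expected change is an estimated 2.0-fold higher number from compound 2 to compound 3 (0.30 log units; within the scatter). For compound 3 the estimated value is 2800 nM, with an expected range of 1100 nM to 7500 nM.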

Compound 3, concentration for 50% growth inhibition: 567 nM
The estimate for compound 3 lay 4.9-fold (0.69 log units) above the measured number; measured number below the stated range.
By their numbers in this assay, from the lowest: compound 3; then compounds 2 and 1 (each within the scatter of the next).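

In this assay hydrogen in place of trifluoromethyl on an aromatic carbon gives a 2.5-fold lower number from compound 2 to compound 3 (0.39 log units; beyond the scatter) and is a modest step beyond the scatter. Among the compounds shown here, it is the first change here that can be read on its own, and it shows that trifluoromethyl at this position is not required for growth inhibition in these cells, since the phenyl of compound 3 does better than the 3-(trifluoromethyl)phenyl of compound 2. No supporting data accompany the step, so it stands as an observation only.

The compounds shown leave open whether a methyl, a methoxy or an amine at this position would match hydrogen or surpass it. They also leave open whether the same change would give a similar step on the urea of compound 1.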